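The compounds below may be only part of what the source reports. "The series", "measured", "known", "first", "only" and "open" are said of these compounds alone.

The measured compounds:
- compound 1, `Nc1ccccc1NC(=O)c1ccc(CSC(=S)N2CCN(c3ccc(F)cc3)CC2)cc1`; in a functional assay on HeLa cells (Homo sapiens) for antiproliferative activity, read by CCK-8 assay, with a stated time of 72 h, tested at 8 uM (on this read-out higher numbers stand for a stronger effect at the one concentration tested and lower numbers for a weaker effect), compound 1 gives 64.5%
- compound 2, `Nc1ccccc1NC(=O)c1ccc(CSC(=S)N2CCN(C3CCCCC3)CC2)cc1`; in this assay compound 2 gives 76.1%

Compound 2 stands highest of the two numbers in this assay. Among the compounds with values here, its nearest neighbour is compound 1, and the one measured step between them, a number 11.6 percentage points higher from compound 1 to compound 2 (beyond the scatter), lies beyond the scatter. Compound 3, `Nc1ccccc1NC(=O)c1ccc(CSC(=S)N2CCN(Cc3ccccc3)CC2)cc1`, has yet to be measured in this assay. The change from compound 2 to compound 3 is benzyl in place of cyclohexyl on an amine nitrogen in a ring. Within the data shown here, no measured step covers this exchange directly. Among the measured compounds shown here, the only step available, a number 11.6 percentage points higher from compound 1 to compound 2 (beyond the scatter), concerns a different exchange on the same ring nitrogen, in which an aromatic group gave way to a non-aromatic one with a modest rise; the benzyl group of compound 3 brings an aromatic ring back, though this change is not the reverse of that step. On this slender basis a small move downward, or none beyond the scatter, is expected for compound 3. The expected step is a number 6.1 percentage points lower from compound 2 to compound 3 (within the scatter). Compound 3 is therefore estimated at 70% in this assay, with a range from 58% to 82%.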

Compound 3, a percentage reported as inhibition, at one concentration (the size of the read-out at that concentration, not a potency): 31.3%
Beside the measured number, compound 3's estimate is 38.7 percentage points above it; measured number outside the range, below it.
By their numbers in this assay, from the lowest: compound 3; then compound 1; then compound 2.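

In this assay, within the data shown here, the group on the amine nitrogen in the ring matters far more than the single earlier step suggested: the exchange for benzyl gives a number 44.8 percentage points lower from compound 2 to compound 3 (beyond the scatter) and also a number 33.2 percentage points lower from compound 1 to compound 3 (beyond the scatter), which places benzyl under both the cyclohexyl and the 4-fluorophenyl group. The presence of an aromatic ring does not sort these compounds, as compound 1 and compound 3 both carry one yet lie far apart, and compound 1 stands against any simple rule that aromatic groups on this nitrogen give low numbers. Nothing available explains why benzyl differs so sharply from the other two groups.

With only three groups at this position, the compounds shown leave open whether the low number belongs to benzyl alone or would also appear with a 4-fluorobenzyl or a 2-phenylethyl group. They also leave open how an unsubstituted phenyl, a cyclohexylmethyl or a small methyl group would behave here, and so whether the aromatic ring of benzyl or its added carbon goes with the drop.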